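This account rests on a few compounds, and the source may have more. Where it says the series, first, only, none or still open, it means among the compounds named here.

Going by the values given here, compound 2 `CCSc1nc(=O)ccn1[C@@H]1O[C@H](COP(=O)(O)O)[C@@H](O)[C@H]1O` is one of three compounds measured in an in vitro functional assay on 1321-N1 cells for agonist activity at P2Y purinoceptor 2 (Homo sapiens), read by scintillation proximity assay and inositol phosphate accumulation (on this read-out higher numbers stand for an effect only at larger amounts of compound and lower numbers for an effect already at smaller amounts), and it stands second highest among them: in this assay compound 2 gives 1500 nM. Compound 1 `CSc1nc(=O)ccn1[C@@H]1O[C@H](COP(=O)(O)OP(=O)(O)O)[C@@H](O)[C@H]1O` sits closest to it, and in this assay compound 1 gives 523 nM. Compound 3 `O=c1ccn([C@@H]2O[C@H](COP(=O)(O)OP(=O)(O)O)[C@@H](O)[C@H]2O)c(SCc2ccccc2)n1` lies furthest from it, and in this assay compound 3 gives 6200 nM.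

Compound 4 `CCCSc1nc(=O)ccn1[C@@H]1O[C@H](COP(=O)(O)O)[C@@H](O)[C@H]1O` has not yet been measured. It differs from compound 2 by methyl in place of hydrogen on a saturated chain carbon, two bonds along the chain from a sulfur. Among the compounds with values here, the only measured step that touches the same region is the one from compound 1 to compound 3, where a phenyl in place of hydrogen on a saturated chain carbon bound to a sulfur gave a 12-fold higher number from compound 1 to compound 3 (1.07 log units; beyond the scatter). That step is far larger in what it adds than the change from compound 2 to compound 4, which only lengthens ethylsulfanyl to propylsulfanyl. The direction is nonetheless suggested: a larger group on that chain went with a higher number in compound 3.

On this basis a small rise is expected for compound 4, in the order of a 1.7-fold higher number from compound 2 to compound 4 (0.22 log units; within the scatter), close to the scatter but leaning upward. The estimated number for compound 4 in this assay is therefore 2500 nM, expected to fall between 1000 nM and 7000 nM.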

Compound 4, half-maximal effective concentration: 4800 nM
Beside the measured number, compound 4's estimate is 1.9-fold (0.28 log units) below it; low and high end bracket the measured number.
By their numbers in this assay, from the lowest: compound 1; then compound 2; then compounds 4 and 3 (each within the scatter of the next).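

Lengthening ethylsulfanyl to propylsulfanyl gave a 3.2-fold higher number from compound 2 to compound 4 (0.51 log units; beyond the scatter) in this assay, showing that a methyl alone, on a saturated chain carbon, two bonds along the chain from a sulfur, is enough to move the number beyond the scatter. Going by these compounds alone, until now, the only step read in this region was the much larger phenyl change, a 12-fold higher number from compound 1 to compound 3 (1.07 log units; beyond the scatter), so the effect of a minimal addition on this chain was unknown; both steps now point the same way, on two different cores, and neither of the two goes against that direction. The compounds shown offer no measurement that could explain the rise.

Still open, as far as these compounds go, is whether a longer chain such as butylsulfanyl would carry the rise further on the core of compound 2, or whether a hydroxyl, an amine or a carboxylic acid at the end of the chain would change its direction. Also open is how the same methyl change would read on the core of compound 1, since the two steps shown do not share a core.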